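A few compounds are considered here, and "the series" means these few. Any claim that something is new, unique, unknown or untested is made for them only; others in the source may bear on it.

Compound 1, with the structure `C=CCOc1cc(OC)c(C(=O)/C=C/c2ccc(F)cc2)c(OCC=C)c1`, was examined in a toxicity assay on cells (Macrophage, Mus musculus, strain BALB/c) for cytotoxicity, read by MTT assay (on this read-out higher numbers stand for weaker inhibition and lower numbers for stronger inhibition), and gave 13800 nM. Two further compounds built on a different core were read in the same way: compound 3 `COc1cc(O)cc(O)c1C(=O)/C=C/c1ccccc1Br` gave 14600 nM, and compound 2 `COc1cc(O)cc(O)c1C(=O)/C=C/c1ccc(C(F)(F)F)cc1` gave 17100 nM. Of the three numbers, compound 1 has the smallest, yet both compound 3 and compound 2 sit within the usual scatter of it, so no order among the three can be drawn from these values.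

The next compound, compound 4 `C=CCOc1cc(OC)c(C(=O)/C=C/c2ccccc2Br)c(OCC=C)c1`, keeps the core of compound 1 and differs from it in one place: 2-bromophenyl in place of 4-fluorophenyl on a double-bonded chain carbon bound to a double-bonded chain carbon. Within the data shown here, no pair of measured compounds shares this exact change, so there is no measured step to lean on. What the data do offer is that compound 3, which carries the 2-bromophenyl group on its own core, and compound 2 both fall close to compound 1 in this assay.

On that basis the step expected in a 1.0-fold higher number from compound 1 to compound 4 (0.01 log units; within the scatter) is none beyond the scatter, with no direction favoured. Compound 4 is therefore estimated to give 14000 nM in this assay, with a likely range from 7000 nM to 28000 nM.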

Compound 4, half-maximal inhibitory concentration: 5400 nM
For compound 4 the middle estimate is 2.6-fold (0.41 log units) above the measured one; the whole stated range lies above it.
By their numbers in this assay, from the lowest: compound 4; then compounds 1, 3 and 2 (each within the scatter of the next).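

The earlier compounds shown here included no pair differing in one place, so they could say nothing about this position. Among these compounds, the exchange of 4-fluorophenyl for 2-bromophenyl, on a double-bonded chain carbon bound to a double-bonded chain carbon, now gives a first readable step in this assay, a 2.6-fold lower number from compound 1 to compound 4 (0.41 log units; beyond the scatter), in the direction of stronger inhibition, and so shows that the value on the core of compound 1 responds to which substituted phenyl group stands at this place, even though the two groups match in their counts of heavy atoms, hydrogen-bond donors and hydrogen-bond acceptors. No measurement is available that would account for this step.

This single step changes both the halogen and where it sits on the phenyl ring, so the compounds shown cannot separate the share of each. They also leave open how this place would respond to a phenyl ring carrying an amine or a carboxylic acid, and whether the same exchange would give a similar step on the core shared by compound 2 and compound 3.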